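Oxazolyl for ureido on the thiazole: expected step

A few compounds are considered here, and "the series" means these few. Any claim that something is new, unique, unknown or untested is made for them only; others in the source may bear on it.

Measured so far:
compound 1, `NC(=O)c1nnc(N2CCC(Oc3ccccc3C(F)(F)F)CC2)s1`: 3 nM
compound 2, `NC(=O)Nc1cnc(N2CCC(Oc3ccccc3C(F)(F)F)CC2)s1`: 150 nM

In an assay on microsomes from liver (strain Wistar) for inhibition of acyl-CoA desaturase 1 (Rattus norvegicus), read by HPLC, with stated times of 1 h and 60 min (a higher number here means a weaker inhibitor, a lower number a stronger inhibitor), compound 2 gives 150 nM, the higher of the two numbers; compound 1 gives 3 nM, a gap beyond the scatter. Compound 3, `FC(F)(F)c1ccccc1OC1CCN(c2ncc(-c3ncco3)s2)CC1`, carries the change (1,3-oxazol-2-yl in place of ureido on an aromatic carbon). Among the compounds with values here, no measured pair shows this exchange, so the step from compound 2 to compound 3 cannot be read from the data; an inhibitor of intermediate strength is expected, with the estimated step of a 3.8-fold lower number from compound 2 to compound 3 (0.57 log units; beyond the scatter). For compound 3 the estimate is 40 nM, within 8 nM to 200 nM.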

Compound 3, half-maximal inhibitory concentration: 14 nM
Beside the measured number, compound 3's estimate is 2.9-fold (0.46 log units) above it; the range from low to high includes it.
By their numbers in this assay, from the lowest: compound 1; then compound 3; then compound 2.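

At this aromatic carbon next to the ring sulfur, 1,3-oxazol-2-yl in place of ureido gives an 11-fold lower number from compound 2 to compound 3 (1.03 log units; beyond the scatter) and removes the hydrogen-bond donors of ureido, so these donors are not required for inhibition at this position. The position also accepts a five-membered aromatic ring. Nothing at hand explains the size of this step.

Open, going by these compounds, is whether a phenyl ring, lacking the hetero atoms of 1,3-oxazol-2-yl, would match compound 3 in this series. Also open, on these data alone, is how an amine or a carboxylic acid would fare on this carbon.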